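This account rests on a few compounds, and the source may have more. Where it says the series, first, only, none or still open, it means among the compounds named here.

Three compounds have so far been measured in a functional assay on MCF7 cells (Homo sapiens) for inhibition, read by colorimetric assay and MTT assay, with a stated time of 72 h; on this read-out lower numbers stand for stronger inhibition and higher numbers for weaker inhibition:

Compound 1, `C=CCCCCOc1cc2ccccc2cc1-c1cnc(OCCC=C)n1C`, gives 25000 nM.
Compound 2, `C=CCCCCOc1cc2ccccc2cc1-c1cnc(OCCCCC=C)n1C`, gives 37000 nM.
Compound 3, `C=CCCCCOc1ccccc1-c1cnc(S(=O)(=O)c2ccccc2)n1C`, gives 25000 nM.

Compound 4, `C=CCCOc1ccccc1-c1cnc(S(=O)(=O)c2ccccc2)n1C`, has not yet been measured. It is made from compound 3 by one change: vinyl in place of but-3-en-1-yl on a saturated chain carbon, two bonds along the chain from an oxygen on an aromatic ring. The same change, at the same place, links compound 2 to compound 1, where it gave a 1.5-fold lower number from compound 2 to compound 1 (0.17 log units; within the scatter). The difference between the core of compound 2 and the core of compound 3 is not broken down here. Compound 4 is expected to show a 1.3-fold lower number from compound 3 to compound 4 (0.10 log units; within the scatter) because the same change gave a 1.5-fold lower number from compound 2 to compound 1 (0.17 log units; within the scatter), a step that stayed within the scatter. Compound 4 is therefore estimated at 20000 nM in this assay, with a range from 8000 nM to 50000 nM.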

Compound 4, half-maximal inhibitory concentration: 67000 nM
Estimate against measurement, compound 4: 3.4-fold (0.53 log units) below, outside the stated range (above it).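

In this assay, putting vinyl in place of but-3-en-1-yl on the core of compound 3 gives a 2.7-fold higher number from compound 3 to compound 4 (0.43 log units; beyond the scatter). The change does not carry over with the same result from one core to the other: the same change on two cores in this assay, a 1.5-fold lower number (0.17 log units; within the scatter) from compound 2 to compound 1 and a 2.7-fold higher number (0.43 log units; beyond the scatter) from compound 3 to compound 4, 4.0-fold (0.60 log units) apart, beyond the scatter of two such steps

Going by these compounds alone, this rests on only one pair of compounds for each core, and it does not show which difference between the cores matters or why the two steps part. The compounds shown leave open how a chain longer than hex-5-en-1-yl would behave on either core. They also leave open what a chain ending in an amine or a carboxylic acid would do at this place.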